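Replacing the Amino Group of Compound 2

The source may report more compounds than this note shows. Statements on the series, on what has been measured and on what is new or still open speak of the compounds shown alone.

In a functional assay on HeLa cells (Homo sapiens) for cytotoxicity, read by neutral red uptake, with a stated time of 3 days (on this read-out higher numbers stand for weaker inhibition and lower numbers for stronger inhibition), compound 1 `Nc1ccc(-c2cc(=O)c3c(N)c(F)cc(F)c3o2)cc1F` gives > 100000 nM, which is a limit of the assay and not a number. For the measured compounds named here, compound 2 `Nc1ccc(-c2cc(=O)c3c(N)c(F)c(N)c(F)c3o2)cc1F` gives 19000 nM, the only actual number so far. Compound 3 `CN(C)CCC(=O)OCc1c(F)c(N)c2c(=O)cc(-c3ccc(N)c(F)c3)oc2c1F` carries (((2-(dimethylamino)ethyl)carbonyl)oxy)methyl in place of amino on an aromatic carbon, ortho to two fluoro groups ((((2-(dimethylamino)ethyl)carbonyl)oxy)methyl in place of amino on an aromatic carbon). Going by the values given here, the one measured step bearing on this change is an at least 5.2-fold lower number from compound 1 to compound 2 (0.72 log units; beyond the scatter), which came with amino in place of hydrogen on that same carbon. Going by these compounds, its full size stays open, as the limit of > 100000 nM in this assay, at which 1 of the 2 values shown sits, shows. Among the compounds with values here, that amino leaves again in compound 3, and no measured compound carries the entering group, so a modest move towards a higher number is expected in this assay. The expected step is a 2.4-fold higher number from compound 2 to compound 3 (0.37 log units; beyond the scatter). For compound 3 the estimated value is 45000 nM, with an expected range of 10000 nM to 150000 nM.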

Compound 3, half-maximal inhibitory concentration: 11000 nM
Beside the measured number, compound 3's estimate is 4.1-fold (0.61 log units) above it; the measured number falls inside the stated range.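

In this assay, for the compounds shown here, putting (((2-(dimethylamino)ethyl)carbonyl)oxy)methyl in place of amino gives a 1.7-fold lower number from compound 2 to compound 3 (0.24 log units; within the scatter), so at this carbon, ortho to two fluoro groups, a group of 9 heavy atoms stands level with the single amino group. Set against hydrogen on the same carbon, the entering group comes with an at least 9.0-fold lower number from compound 1 to compound 3 (0.95 log units; beyond the scatter), which shows that amino is not the only group on this carbon to go with a number beyond the scatter from the hydrogen compound. Compound 1 gives > 100000 nM, a limit of the assay and not a number, and the full size of that step stays open: the limit of > 100000 nM in this assay, at which 1 of the 3 values shown sits.

Going by these compounds, whether a hydroxymethyl group, or a chain ending in a carboxylic acid instead of the dimethylamino group, would read the same on this carbon remains open. So does whether the level standing of amino and the entering group holds in any read-out other than this assay.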